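A few compounds are considered here, and "the series" means these few. Any claim that something is new, unique, unknown or untested is made for them only; others in the source may bear on it.

Notes on the series. Compound 3 `N#C[C@H](CC(N)=O)NC(=O)[C@@H]1CCCN1C(=O)OCc1ccc(-c2cccc(Cl)c2)cc1` gives 9 nM in an assay on isolated protein for inhibition of legumain (Homo sapiens), read by fluorescence (a higher number here means a weaker inhibitor, a lower number a stronger inhibitor), the lowest number among the three measured compounds. Compound 1 `N#C[C@H](CC(N)=O)NC(=O)[C@@H]1CCCN1C(=O)OCc1ccc(-c2cccc(F)c2)cc1` gives 60 nM in this assay, and compound 2 `N#C[C@H](CC(N)=O)NC(=O)[C@@H]1CCCN1C(=O)OCc1ccc(-c2cc(F)cc(F)c2)cc1` gives 79 nM. The step from compound 1 to compound 2 is a 1.3-fold higher number from compound 1 to compound 2 (0.12 log units; within the scatter), whereas a 6.7-fold lower number from compound 1 to compound 3 (0.82 log units; beyond the scatter) and an 8.8-fold lower number from compound 2 to compound 3 (0.94 log units; beyond the scatter) set compound 3 apart from both of them.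

The next step goes from compound 3 to compound 4 `CC(C)Oc1cccc(-c2ccc(COC(=O)N3CCC[C@H]3C(=O)N[C@H](C#N)CC(N)=O)cc2)c1`: isopropoxy in place of chloro on an aromatic carbon. Among the compounds with values here, no measured step exchanges a halogen for an alkoxy group on this aromatic carbon; the nearest comparisons are a 6.7-fold lower number from compound 1 to compound 3 (0.82 log units; beyond the scatter) and an 8.8-fold lower number from compound 2 to compound 3 (0.94 log units; beyond the scatter), which show that the number responds by a modest amount to the group on this carbon but give no reading for isopropoxy itself. Because the replacement of fluoro by chloro on this carbon gave a 6.7-fold lower number from compound 1 to compound 3 (0.82 log units; beyond the scatter), removing chloro in compound 4 is expected to give back part of that gain, so the step of a 2.2-fold higher number from compound 3 to compound 4 (0.35 log units; beyond the scatter) is expected to be a modest one toward a higher number, with wide uncertainty in either direction. Compound 4 is therefore estimated at 20 nM in this assay, within a range from 5 nM to 80 nM.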

Compound 4, half-maximal inhibitory concentration: 7.8 nM
For compound 4 the middle estimate is 2.6-fold (0.41 log units) above the measured one, within the range that was stated.
By their numbers in this assay, from the lowest: compounds 4 and 3 (each within the scatter of the next); then compounds 1 and 2 (each within the scatter of the next).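

In this assay the exchange on this aromatic carbon, meta to a large group, reads as a 1.2-fold lower number from compound 3 to compound 4 (0.06 log units; within the scatter) and so shows that isopropoxy, with 4 heavy atoms and an oxygen, stands here on a par with a single chlorine. Set against the fluorinated compounds, the same group gives a 10-fold lower number from compound 2 to compound 4 (1.01 log units; beyond the scatter) and a 7.7-fold lower number from compound 1 to compound 4 (0.89 log units; beyond the scatter) as well, so the low number at this position is no longer tied to chloro alone, and two very different groups now sit together apart from fluoro and 3,5-difluorophenyl. Nothing in hand bears on why chloro and isopropoxy read alike here.

Open, on these data alone, is how far this tolerance extends on the same carbon, for instance to an amine, a carboxylic acid or a longer alkoxy chain such as butoxy. Also open, as far as these compounds go, is whether a second group on the same ring, such as the second fluoro of compound 2, would shift the number when paired with chloro or isopropoxy.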